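Replacing Benzyl with 4-Nitrophenyl on the Triazole Series

The source may report more compounds than this note shows. Statements on the series, on what has been measured and on what is new or still open speak of the compounds shown alone.

Of the compounds shown here, three sharing one core have been measured in a functional assay on the whole organism (plasma, strain Wistar) with Rattus norvegicus as the target, with a stated time of 15 days, at a dose of 100 mg/kg by the oral route; on this read-out higher numbers stand for a stronger effect at the one dose given and lower numbers for a weaker effect. Compound 1 `Cc1nc(COc2ccc(/C=C3\SC(=O)NC3=O)cc2)cs1` gives 22.9%. Compound 2 `O=C1NC(=O)/C(=C/c2ccc(OCc3csc(-c4ccccc4)n3)cc2)S1` gives 29.7%, and the change from methyl to phenyl on an aromatic carbon yields a number 6.8 percentage points higher from compound 1 to compound 2 (within the scatter). Compound 3 `O=C1NC(=O)/C(=C/c2ccc(OCCSc3nnc(Cc4ccccc4)[nH]3)cc2)S1` gives 34.4%, the highest of the three numbers, although its gap to compound 2 lies within the scatter and only its gap to compound 1 lies beyond it.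

Compound 4 `O=C1NC(=O)/C(=C/c2ccc(OCCSc3nnc(-c4ccc([N+](=O)[O-])cc4)[nH]3)cc2)S1` differs from compound 3 in one place: 4-nitrophenyl in place of benzyl on an aromatic carbon. Among the compounds with values here, the only measured step that bears on this change is the one from compound 1 to compound 2, a swap of a substituent on an aromatic carbon, and that step stayed within the scatter. Within the data shown here, no measured step concerns a nitro group at all. Compound 4 is therefore expected to move by no more than a number 0.6 percentage points higher from compound 3 to compound 4 (within the scatter), a shift that is not expected to exceed the scatter. The estimate for compound 4 in this assay is 35%, within a range from 22% to 48%.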

Compound 4, a percentage reported as activity, at one dose (the size of the read-out at that dose, not a potency): 18%
The estimate for compound 4 lay 17 percentage points above the measured number; the measured number lies below the stated range.
By their numbers in this assay, from the lowest: compounds 4, 1, 2 and 3 (each within the scatter of the next, the first and the last beyond it).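

In this assay, 4-nitrophenyl in place of benzyl on an aromatic carbon between two ring nitrogen atoms gives a number 16.4 percentage points lower from compound 3 to compound 4 (beyond the scatter). Within the data shown here, this shows that the group at this position can change the read-out by more than the scatter, whereas the only earlier step of this kind, at a different place on a different compound pair, stayed within it: a number 6.8 percentage points higher from compound 1 to compound 2 (within the scatter). Nothing measured here accounts for the lower number.

The change removes benzyl and brings in a nitro-bearing phenyl in one step, so the compounds shown do not separate the loss of the benzyl carbon from the arrival of the nitro group. Unsubstituted phenyl at this position, or 4-aminophenyl with an amine in place of the nitro group, would each bear on that question.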